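Oxime ether chain variation on the shared core

A few compounds are considered here, and "the series" means these few. Any claim that something is new, unique, unknown or untested is made for them only; others in the source may bear on it.

Measured compounds:
compound 1 `Cc1cc2c(F)c(Oc3ncnc(N)c3/C=N/OCCCO)ccc2[nH]1`, 336 nM
compound 2 `COCCO/N=C/c1c(N)ncnc1Oc1ccc2[nH]c(C)cc2c1F`, 233 nM
compound 3 `CNCCO/N=C/c1c(N)ncnc1Oc1ccc2[nH]c(C)cc2c1F`, 345 nM

In a functional assay on A-375 cells (Homo sapiens) for antiproliferative activity (on this read-out lower numbers stand for stronger inhibition and higher numbers for weaker inhibition), compound 3 gives the highest of the three numbers, yet all three sit within the scatter of one another: a 1.0-fold higher number from compound 1 to compound 3 (0.01 log units; within the scatter), a 1.5-fold higher number from compound 2 to compound 3 (0.17 log units; within the scatter), and a 1.4-fold lower number from compound 1 to compound 2 (0.16 log units; within the scatter). Compound 4 `Cc1cc2c(F)c(Oc3ncnc(N)c3/C=N/OCc3ccccc3)ccc2[nH]1` differs from compound 3 by phenyl in place of (methylamino)methyl on a saturated chain carbon bound to an oxygen on an unsaturated carbon. Going by the values given here, no measured step exchanges a chain terminus for a ring, so the only guidance is that the three exchanges at this chain end all stayed within the scatter. The step of a 1.1-fold lower number from compound 3 to compound 4 (0.03 log units; within the scatter) is therefore expected to stay within the scatter as well, with no direction preferred. Compound 4 is estimated at 320 nM, with a range from 110 nM to 950 nM that is widened for the untested ring.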

Compound 4, half-maximal inhibitory concentration: 62 nM
Compound 4: the middle estimate sits 5.2-fold (0.71 log units) above what was measured; the whole stated range lies above it.
By their numbers in this assay, from the lowest: compound 4; then compounds 2, 1 and 3 (each within the scatter of the next).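

In this assay, going by these compounds alone, phenyl on a saturated chain carbon bound to an oxygen on an unsaturated carbon gives the first step at this chain end that leaves the scatter (a 5.6-fold lower number from compound 3 to compound 4 (0.75 log units; beyond the scatter); a 3.8-fold lower number from compound 2 to compound 4 (0.57 log units; beyond the scatter); a 5.4-fold lower number from compound 1 to compound 4 (0.73 log units; beyond the scatter)). The chain ends of compounds 1, 2 and 3 stay within the scatter of one another, so compound 4 alone stands apart, and it does so against each of them. Nothing at hand explains this separation.

From the compounds shown here alone, whether it depends on the aromatic ring or on any six-membered carbon ring remains open, as a cyclohexyl group would test. A longer chain ending in phenyl would show whether the ring's distance from the oxime oxygen matters.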